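The source may report more compounds than this note shows. Statements on the series, on what has been measured and on what is new or still open speak of the compounds shown alone.

In a functional assay on A549 cells (Homo sapiens) for antiproliferative activity, read by MTT assay, with a stated time of 72 h (a higher number here means a weaker inhibitor, a lower number a stronger inhibitor), the measured compounds read:
- compound 1 (`Nc1nc(N)c2cc(CSC(=S)N3CCN(C4CCCCC4)CC3)ccc2n1`) gives 4710 nM
- compound 2 (`Cc1ccccc1N1CCN(C(=S)SCc2ccc3nc(N)nc(N)c3c2)CC1`) gives 3920 nM
- compound 3 (`Nc1nc(N)c2cc(CSC(=S)N3CCN(c4ccc(Cl)cc4)CC3)ccc2n1`) gives 5210 nM

Compound 3 lies within the scatter of both other compounds (a 1.1-fold higher number from compound 1 to compound 3 (0.04 log units; within the scatter)) (a 1.3-fold higher number from compound 2 to compound 3 (0.12 log units; within the scatter)). Compound 4 (`Nc1nc(N)c2cc(CSC(=S)N3CCN(c4ccc(Cl)c(Cl)c4)CC3)ccc2n1`) has chloro in place of hydrogen on an aromatic carbon, ortho to a chloro group and meta to a large group (chloro in place of hydrogen on an aromatic carbon). Going by the values given here, no measured step adds this chloro. The nearest evidence is the change of the same nitrogen substituent, which stayed within the scatter in all three steps, including (a 1.2-fold lower number from compound 1 to compound 2 (0.08 log units; within the scatter)). No step beyond the scatter is therefore expected in this assay, and no direction can be called. The expected step is small (a 1.2-fold lower number from compound 3 to compound 4 (0.06 log units; within the scatter)). For compound 4 the estimate is (4500 nM), with an expected range from 2200 nM to 8500 nM only.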

Compound 4, half-maximal inhibitory concentration: 2940 nM
Compound 4: middle estimate off by 1.5-fold (0.18 log units), on the high side; measured number inside the range.
By their numbers in this assay, from the lowest: compounds 4, 2, 1 and 3 (each within the scatter of the next).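

In this assay, chloro in place of hydrogen on an aromatic carbon, ortho to a chloro group, stays within the scatter (a 1.8-fold lower number from compound 3 to compound 4 (0.25 log units; within the scatter)). The 3,4-dichlorophenyl group also stays within the scatter against 2-methylphenyl (a 1.3-fold lower number from compound 2 to compound 4 (0.12 log units; within the scatter)) and cyclohexyl (a 1.6-fold lower number from compound 1 to compound 4 (0.20 log units; within the scatter)), so this position accepts the added chloro with no readable shift. Nothing available explains these steps. Open, from the compounds shown here alone, is whether a methoxy group or an amine at this position, or a longer chain on the ring nitrogen, would give a step beyond the scatter.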